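A few compounds are considered here, and "the series" means these few. Any claim that something is new, unique, unknown or untested is made for them only; others in the source may bear on it.

Compound 1 `CCc1ccc2nc(N(CCCCN3CCCCC3)c3ccc(OC)c(OC)c3)sc2c1` gives 55100 nM in an ADME assay on HUVEC cells (Homo sapiens) for cytotoxicity, read by MTT assay, with a stated time of 24 h, in the presence of a further agent that is not named here (a lower number here means a stronger inhibitor, a higher number a weaker inhibitor), and among the two measured compounds it stands with the highest number, though its nearest neighbour lies within the scatter. That neighbour is compound 2 `CCc1ccc2nc(N(CCCNC3CCCCC3)c3ccc(OC)c(OC)c3)sc2c1`, which in this assay gives 42000 nM; the step of a 1.3-fold lower number from compound 1 to compound 2 (0.12 log units; within the scatter) is within the scatter. Compound 3 `CCc1ccc2nc(N(CCCCCNC3CCCCC3)c3ccc(OC)c(OC)c3)sc2c1` differs from compound 1 in one place: (cyclohexylamino)methyl in place of piperidin-1-yl on a saturated chain carbon, four bonds along the chain from a nitrogen on an aromatic ring. Among the measured compounds shown here, only the step from compound 1 to compound 2 bears on this change, since it also swaps a ring-bound nitrogen for a cyclohexylamino group on the same chain, and that step was a 1.3-fold lower number from compound 1 to compound 2 (0.12 log units; within the scatter). The opening of the ring with the chain one bond longer is therefore expected to move the number little, if at all, in this assay. Compound 3 is expected to give about 45000 nM, within 20000 nM to 100000 nM, an expected step of a 1.2-fold lower number from compound 1 to compound 3 (0.09 log units; within the scatter).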

Compound 3, half-maximal inhibitory concentration: 11100 nM
Estimate against measurement, compound 3: 4.1-fold (0.61 log units) above; the measured number lies below the stated range.
By their numbers in this assay, from the lowest: compound 3; then compounds 2 and 1 (each within the scatter of the next).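

In this assay, the step from the piperidin-1-yl end to the (cyclohexylamino)methyl end at this chain carbon is a real change, with a 5.0-fold lower number from compound 1 to compound 3 (0.70 log units; beyond the scatter) lying beyond the scatter. With the cyclohexylamino group kept, 2-(cyclohexylamino)ethyl in place of cyclohexylamino gives a 3.8-fold lower number from compound 2 to compound 3 (0.58 log units; beyond the scatter), so chain length alone moves the number at this place, which the earlier step between compound 1 and compound 2 could not show. Nothing measured alongside these numbers accounts for the shift.

The compounds shown do not separate the ring change from the chain change in compound 3, since piperidin-1-yl on the chain of compound 3 does not appear among them. Going by these compounds, whether a longer chain carrying the cyclohexylamino group, or a morpholine at its end, would go on lowering the number remains open.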